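Replacing the isobutoxyphenyl arm: a cytotoxicity check

A few compounds are considered here, and "the series" means these few. Any claim that something is new, unique, unknown or untested is made for them only; others in the source may bear on it.

Among the measured compounds shown here, compound 2 `CCOC(=O)CCCCCOc1cccc(CN(C(=O)c2ccc(-c3cccc(OCC(C)C)c3)cc2)C(C)C)c1` is one of three compounds measured so far in an ADME assay on HepG2 cells (Homo sapiens) for cytotoxicity, read by CellTiter-Glo and resazurin assay, with a stated time of 72 h; on this read-out higher numbers stand for an effect only at larger amounts of compound and lower numbers for an effect already at smaller amounts. In this assay compound 2 gives > 26000 nM, which is a limit of the assay rather than a number. Compound 1 `CC(C)COc1cccc(-c2ccc(C(=O)N(Cc3cccc(OCCCCCC(=O)O)c3)C(C)C)cc2)c1` gives > 26000 nM, also only a limit. Compound 3 `CCOC(=O)CCCCCOc1cccc(CN(C(=O)c2ccc(-c3cccc(OCc4ccccc4)c3)cc2)C(C)C)c1` gives > 26000 nM, again a limit. Thus (the limit of > 26000 nM in this assay, at which 3 of the 3 values shown sit). The step that the two limits leave unreadable from compound 1 to compound 2 and the step that the two limits leave unreadable from compound 2 to compound 3 are both hidden behind these limits, so neither can be read in size or direction.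

Compound 4 `CCOC(=O)CCCCCOc1cccc(CN(C(=O)c2ccc(-c3cc(F)cc(OC)c3)cc2)C(C)C)c1` has not yet been measured. It differs from compound 2 in that (3-fluoro-5-methoxyphenyl in place of 3-(isobutoxy)phenyl on an aromatic carbon). For the measured compounds named here, none of the measured steps touches this part of the structure, and none is readable in any case. With every shown value sitting at the limit, compound 4 is expected to sit there as well, and the step that the limit leaves unreadable from compound 2 to compound 4 is expected to stay within the scatter. Compound 4 is estimated at 30000 nM, in the range 15000 nM to 80000 nM, and is expected to be reported as a limit once more.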

Compound 4, half-maximal effective concentration: > 26000 nM
Compound 4 gave a limit, no number (the forecaster's own chance of this, stated with the estimate: 85%); the middle value does not contradict the limit.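

The step between compound 2 and compound 4 cannot be read in this assay, since neither compound gives a number, only a limit: the limit of > 26000 nM in this assay, at which 4 of the 4 values shown sit. The compounds shown leave open at what concentration any of them would affect the cells, and whether exchanging 3-(isobutoxy)phenyl for 3-fluoro-5-methoxyphenyl changes that concentration.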